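The source may report more compounds than this note shows. Statements on the series, on what has been measured and on what is new or still open speak of the compounds shown alone.

In an assay on HEK293 cells for inhibition of N-acylethanolamine-hydrolyzing acid amidase (Rattus norvegicus), read by LC-MS, with a stated time of 30 min (on this read-out higher numbers stand for weaker inhibition and lower numbers for stronger inhibition), the three measured compounds stand as follows.
Compound 1 `O=C(CCCCCCc1ccccc1)N1CCCC1` gives 12900 nM.
Compound 2 `O=C(CCCCCCc1ccc(F)cc1)N1CCCC1` gives 8000 nM.
Compound 3 `O=C(CCCCCCc1ccccn1)N1CCCC1` gives only a limit of the assay, > 100000 nM.

Compound 3 thus has no number of its own; it sits at the limit of > 100000 nM in this assay, at which 1 of the 3 values shown sits. The unmeasured compound 4 `O=C(CCCCCCc1ccsc1)N1CCCC1` differs from it in one place: thiophen-3-yl in place of pyridin-2-yl on a saturated chain carbon, six bonds along the chain from a carbonyl carbon. Within the data shown here, two measured steps bear on this change. The step of a 1.6-fold lower number from compound 1 to compound 2 (0.21 log units; within the scatter) shows that a small change on the aromatic ring leaves this assay unmoved. The step of an at least 7.7-fold higher number from compound 1 to compound 3 (0.88 log units; beyond the scatter) shows that exchanging phenyl for pyridin-2-yl on the same chain carbon pushes the value off the measurable scale. Compound 4 carries a five-membered aromatic ring with one hetero atom in that position, neither the phenyl of compound 1 nor the pyridin-2-yl of compound 3, so the two steps bracket it without settling it. The expectation is that compound 4 returns to a measurable number and that the step of an at least 5.0-fold lower number from compound 3 to compound 4 (0.69 log units; beyond the scatter) is a lower number, that is, stronger inhibition than the limit of compound 3. Compound 4 is therefore estimated at 20000 nM, within a range from 6000 nM to 100000 nM.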

Compound 4, half-maximal inhibitory concentration: 13200 nM
Estimate against measurement, compound 4: 1.5-fold (0.18 log units) above; the measured number falls inside the stated range.
By their numbers in this assay, from the lowest: compounds 2, 1 and 4 (each within the scatter of the next). At a limit, above all of these: compound 3.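

In this assay, thiophen-3-yl on a saturated chain carbon, six bonds along the chain from a carbonyl carbon, gives a measurable number where pyridin-2-yl does not, with an at least 7.5-fold lower number from compound 3 to compound 4 (0.87 log units; beyond the scatter). Set against the phenyl group at the same place, the new ring shows a 1.0-fold higher number from compound 1 to compound 4 (0.01 log units; within the scatter), so a five-membered aromatic ring can take the place of phenyl here without a change beyond the scatter, and leaving phenyl does not in itself push the value off the scale. The first of these steps gives only a lower bound on its size, because compound 3 has a limit of the assay and not a number: the limit of > 100000 nM in this assay, at which 1 of the 4 values shown sits.

As far as these compounds go, what remains open is whether pyridin-3-yl or pyridin-4-yl at this place would reach the same limit as pyridin-2-yl, or whether the nitrogen must sit as it does in pyridin-2-yl. Also open, from the compounds shown here alone, is whether thiophen-2-yl or furan-3-yl would match thiophen-3-yl, and whether any of these rings would behave the same way on a longer chain.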